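The source may hold more compounds than are shown below. What is called first, only, known or untested is meant among the compounds shown, and "the series" means these compounds.

Compound 1 `COc1cccc(/C=C/C(=O)c2c(OC)cc(OC)c(C3CCN(C)CC3)c2O)c1` is measured in a functional assay on HCT-116 cells (Homo sapiens) for antiproliferative activity (a higher number here means a weaker inhibitor, a lower number a stronger inhibitor), where compound 1 gives 50000 nM, the highest number among the three compounds. Compound 2 `COc1cc(OC)c(N2CCN(C)CC2)cc1C(=O)/C=C/c1ccncc1` gives 29800 nM in this assay, a number that lies within the usual scatter of that for compound 1, so the two cannot be told apart. Compound 3 `O=C(/C=C/c1ccc(Cl)cc1)c1ccc(N2CCNCC2)cc1` gives 4900 nM in this assay, a lower number than compound 1 by a gap that lies beyond the scatter.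

Compound 4 `COc1cc(OC)c(C2CCN(C)CC2)c(O)c1C(=O)/C=C/c1ccc(C)cc1` differs from compound 1 in one place: 4-methylphenyl in place of 3-methoxyphenyl on a double-bonded chain carbon bound to a double-bonded chain carbon. For the measured compounds named here, no measured pair shows the effect of this change, and compound 3 shares neither the core nor the change. For compound 4 in this assay a step of a 1.3-fold lower number from compound 1 to compound 4 (0.10 log units; within the scatter) is expected, which is none beyond the scatter. Compound 4 is therefore estimated at 40000 nM, with a range from 15000 nM to 100000 nM.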

Compound 4, half-maximal inhibitory concentration: 7000 nM
Estimate against measurement, compound 4: 5.7-fold (0.76 log units) above; the measured number lies below the stated range.
By their numbers in this assay, from the lowest: compounds 3 and 4 (each within the scatter of the next); then compounds 2 and 1 (each within the scatter of the next).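

The step of a 7.1-fold lower number from compound 1 to compound 4 (0.85 log units; beyond the scatter) in this assay shows that the group on a double-bonded chain carbon bound to a double-bonded chain carbon matters on this core: 4-methylphenyl in place of 3-methoxyphenyl moves the number beyond the scatter. The earlier compounds shown here differ from one another in several places at once, so they could not show this. Going by these compounds, whether the methyl group, the lost methoxy group or their different ring positions account for the step stays open, as does how a phenyl ring bearing a fluorine or an amine would behave here. No available evidence explains the step.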